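This account rests on a few compounds, and the source may have more. Where it says the series, first, only, none or still open, it means among the compounds named here.

Three compounds share one core and differ only in the group on an aromatic nitrogen. Compound 1 `CCCn1ccc2cc(/C(C)=C/C(=O)Nc3ccccc3OCCCC(=O)O)ccc21` carries a propyl group there, and in an assay on Prostate gland for inhibition of steroid 5-alpha-reductase (Rattus norvegicus) (a lower number here means a stronger inhibitor, a higher number a weaker inhibitor), compound 1 gives 190 nM. Compound 2 `CCCCC(C)n1ccc2cc(/C(C)=C/C(=O)Nc3ccccc3OCCCC(=O)O)ccc21` carries a 1-methylpentyl group, and in this assay compound 2 gives 6 nM, the lowest of the three numbers. Compound 3 `CCCCCC(CCCCC)n1ccc2cc(/C(C)=C/C(=O)Nc3ccccc3OCCCC(=O)O)ccc21` carries a 1-pentylhexyl group, and in this assay compound 3 gives 25 nM. The step of a 32-fold lower number from compound 1 to compound 2 (1.50 log units; beyond the scatter) is large, while the step of a 4.2-fold higher number from compound 2 to compound 3 (0.62 log units; beyond the scatter) is modest, so compound 3 sits between the other two. Compound 4 `CCCCCC(c1ccccc1)n1ccc2cc(/C(C)=C/C(=O)Nc3ccccc3OCCCC(=O)O)ccc21` has not yet been measured; the change from compound 2 is 1-phenylhexyl in place of 1-methylpentyl on an aromatic nitrogen. Going by the values given here, the step bearing most directly on it is the one from compound 2 to compound 3, where 1-pentylhexyl in place of 1-methylpentyl gave a higher number, and compound 4 likewise departs from 1-methylpentyl. For compound 4 a modest rise is therefore expected, a 2.5-fold higher number from compound 2 to compound 4 (0.40 log units; beyond the scatter). For compound 4 the estimate in this assay is 15 nM, between 5 nM and 50 nM.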

Compound 4, half-maximal inhibitory concentration: 25 nM
Compound 4: middle estimate off by 1.7-fold (0.22 log units), on the low side; the measured number falls inside the stated range.
By their numbers in this assay, from the lowest: compound 2; then compounds 3 and 4 (each within the scatter of the next); then compound 1.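

In this assay, a phenyl ring can sit on the branched carbon bound to the aromatic nitrogen, but replacing 1-methylpentyl with 1-phenylhexyl still weakens inhibition (a 4.2-fold higher number from compound 2 to compound 4 (0.62 log units; beyond the scatter)). Phenyl and pentyl on that carbon cannot be told apart here (no change at the digits printed from compound 3 to compound 4 (within the scatter)), so this pair gives no sign that an aromatic ring there differs from a saturated chain. The 1-phenylhexyl group also remains better than propyl (a 7.6-fold lower number from compound 1 to compound 4 (0.88 log units; beyond the scatter)), which means that all three branched groups shown beat propyl, while compound 2 remains the strongest inhibitor of the four.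

Still open, as far as these compounds go, is how a shorter chain alongside the phenyl, as in 1-phenylethyl, or a cyclohexyl ring in place of the phenyl, would behave at this position. No supporting measurement is available to explain these differences.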